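A few compounds are considered here, and "the series" means these few. Any claim that something is new, unique, unknown or untested is made for them only; others in the source may bear on it.

Measured so far in a functional assay on SF-539 cells (Homo sapiens) for antiproliferative activity, with a stated time of 48 h; a lower number here means that less compound is tolerated, a higher number that more compound is tolerated:
compound 1 `Cc1cc(O)c(C2=NN(c3ccc(S(N)(=O)=O)cc3)C(c3ccccc3O)C2)cc1Cl`: 5690 nM
compound 2 `Cc1cc(O)c(C2=NN(c3ccc(S(N)(=O)=O)cc3)C(c3ccccc3Cl)C2)cc1Cl`: 5900 nM
compound 3 `Cc1cc(O)c(C2=NN(c3ccc(S(N)(=O)=O)cc3)C(/C=C/c3ccccc3)C2)cc1Cl`: 37500 nM

Compound 2 has the second highest number of the three. Compound 1 sits within the scatter of it, a 1.0-fold higher number from compound 1 to compound 2 (0.02 log units; within the scatter); compound 3 is the furthest away, a 6.4-fold higher number from compound 2 to compound 3 (0.80 log units; beyond the scatter).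

Compound 4 `COc1ccc(C2CC(c3cc(Cl)c(C)cc3O)=NN2c2ccc(S(N)(=O)=O)cc2)cc1OC` is not yet measured. Its change from compound 2: 3,4-dimethoxyphenyl in place of 2-chlorophenyl on a saturated ring carbon.

Among the measured compounds shown here, two measured steps bear on this position of the shared core. Chloro in place of hydroxy on the aromatic carbon of that ring, a 1.0-fold higher number from compound 1 to compound 2 (0.02 log units; within the scatter), left the number within the scatter. Giving up the aromatic ring for 2-phenylethenyl, a 6.4-fold higher number from compound 2 to compound 3 (0.80 log units; beyond the scatter), gave a modest rise. For the measured compounds named here, compound 4 keeps a six-membered aromatic ring of carbon only on that saturated ring carbon and only exchanges its substituents, so the nearer precedent is the first step. Going by the values given here, no measured compound carries 3,4-dimethoxyphenyl, so the expectation is loose. A step of a 1.0-fold higher number from compound 2 to compound 4 (0.01 log units; within the scatter) is expected, i.e. none beyond the scatter. Compound 4 is estimated at 6000 nM, between 2500 nM and 15000 nM.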

Compound 4, concentration lethal to 50% of the cells: 12000 nM
Estimate against measurement, compound 4: 2.0-fold (0.30 log units) below; the range from low to high includes it.
By their numbers in this assay, from the lowest: compounds 1 and 2 (each within the scatter of the next); then compound 4; then compound 3.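

In this assay, keeping a six-membered aromatic ring of carbon only on this saturated ring carbon does not hold the number in place: 3,4-dimethoxyphenyl in place of 2-chlorophenyl gives a 2.0-fold higher number from compound 2 to compound 4 (0.31 log units; beyond the scatter), and in place of 2-hydroxyphenyl it gives a 2.1-fold higher number from compound 1 to compound 4 (0.32 log units; beyond the scatter), whereas chloro for hydroxy had stayed within the scatter. The rise remains smaller than the one seen with 2-phenylethenyl, as a 3.1-fold lower number from compound 3 to compound 4 (0.49 log units; beyond the scatter) shows, so the three kinds of group at this position give three separate levels, with 2-chlorophenyl and 2-hydroxyphenyl sharing the lowest. No measurement on these compounds accounts for this order.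

As far as these compounds go, whether one methoxy group alone gives the same rise remains open. Also open, from the compounds shown here alone, is how an amine or a carboxylic acid on that aromatic ring would read.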